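Chain shape in the ether series around compound 3

The compounds below may be only part of what the source reports. "The series", "measured", "known", "first", "only" and "open" are said of these compounds alone.

Compound 1 `CC1CCCC(Oc2cccc3ccc(N)nc23)C1` gives 640 nM in an assay on cells with melanin-concentrating hormone receptor 1 (Homo sapiens) as the target, read by radioligand binding; on this read-out higher numbers stand for weaker inhibition and lower numbers for stronger inhibition; compound 2 `Nc1ccc2cccc(OC3CCCCC3)c2n1` gives 361 nM in this assay, and the change from compound 1 to compound 2 is a 1.8-fold lower number from compound 1 to compound 2 (0.25 log units; within the scatter). Compound 3 `CCC(C)COc1cccc2ccc(N)nc12` gives 36 nM in this assay, the lowest of the three numbers, and the change from compound 2 to compound 3 is a 10-fold lower number from compound 2 to compound 3 (1.00 log units; beyond the scatter). Compound 4 `CCCCCOc1cccc2ccc(N)nc12` differs from compound 3 only in this: butyl in place of sec-butyl on a saturated chain carbon bound to an oxygen on an aromatic ring. For the measured compounds named here, no measured step swaps a branched chain for a straight one; the step from compound 2 to compound 3 exchanges cyclohexyl for 2-methylbutyl and the step from compound 1 to compound 2 removes a methyl from a saturated ring carbon, so neither bears directly. Compound 4 is therefore expected to give 40 nM in this assay, between 15 nM and 120 nM. The expected step is a 1.1-fold higher number from compound 3 to compound 4 (0.05 log units; within the scatter), within the scatter.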

Compound 4, half-maximal inhibitory concentration: 580 nM
Compound 4: middle estimate off by 15-fold (1.16 log units), on the low side; measured number outside the range, above it.
By their numbers in this assay, from the lowest: compound 3; then compounds 2, 4 and 1 (each within the scatter of the next).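

For the compounds shown here, on the oxygen of the shared core, the shape of the chain alone matters in this assay: with the same atoms joined differently, 2-methylbutyl to pentyl gives a 16-fold higher number from compound 3 to compound 4 (1.21 log units; beyond the scatter) and so shows a large effect of the branch that no earlier step isolated. Pentyl and cyclohexyl are not separated, with a 1.6-fold higher number from compound 2 to compound 4 (0.21 log units; within the scatter) lying within the scatter, so the low number of compound 3 is not shared by every chain. Nothing available explains this branch effect.

From the compounds shown here alone, whether 3-methylbutyl or a longer branched chain would keep the number of compound 3 remains open.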